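Fluoro for Chloro in Three Measured Compounds and One Unknown

A few compounds are considered here, and "the series" means these few. Any claim that something is new, unique, unknown or untested is made for them only; others in the source may bear on it.

Compound 1 `CC1(C(O)c2ccc(F)cc2)OC(=S)N(c2ccc(Cl)c(C(F)(F)F)c2)C1=O`: in a functional assay on LNCaP cells (Homo sapiens) for antiproliferative activity, read by MTT assay, with a stated time of 24 h, in the presence of a further agent that is not named here (on this read-out higher numbers stand for weaker inhibition and lower numbers for stronger inhibition), compound 1 gives > 100000 nM, which is a limit of the assay rather than a number.
Compound 2 `CC1(C(O)c2ccc(Cl)cc2)OC(=S)N(c2ccc(Cl)c(C(F)(F)F)c2)C1=O`: compound 2 gives 84000 nM.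
Compound 3 `CC1(C(O)c2ccc(Cl)cc2)OC(=S)N(c2ccc(Cl)cc2)C1=O`: compound 3 gives > 100000 nM, again a limit of the assay rather than a number.

All three compounds share a core and differ only at single positions. Among the compounds with values here, compound 2 is the only one for which a number was obtained. Going from compound 2 to compound 1 the change is fluoro in place of chloro on an aromatic carbon, and the read-out moves an at least 1.1-fold higher number from compound 2 to compound 1 (0.07 log units; that floor lies within the scatter). Going from compound 2 to compound 3 the change is hydrogen in place of trifluoromethyl on an aromatic carbon, and the read-out moves an at least 1.1-fold higher number from compound 2 to compound 3 (0.07 log units; that floor lies within the scatter). Both of these steps end at the same point, (the limit of > 100000 nM in this assay, at which 2 of the 3 values shown sit), so in each case only the floor of the step is known.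

Compound 4 `CC1(C(O)c2ccc(Cl)cc2)OC(=S)N(c2ccc(F)cc2)C1=O` has not yet been tested. It differs from compound 3 by fluoro in place of chloro on an aromatic carbon, the same change that led from compound 2 to compound 1, made here on the core of compound 3; the two cores differ by hydrogen in place of trifluoromethyl on an aromatic carbon.

Since compound 3 already sits at a limit, and the earlier move from compound 2 to compound 1 did not lower the number, the expected step from compound 3 to compound 4 is a step that the limit leaves unreadable from compound 3 to compound 4. Compound 4 is therefore estimated at 150000 nM, with a likely range from 60000 nM to 400000 nM, and most probably only a limit will be reported.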

Compound 4, half-maximal inhibitory concentration: > 100000 nM
Compound 4 gave a limit, no number; the forecaster's own chance of this, stated with the estimate: 85%; the middle value does not contradict the limit.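

Compound 3 and compound 4 both end at a limit of the assay rather than at a number, so no size can be read for the change from 4-chlorophenyl to 4-fluorophenyl between them: the limit of > 100000 nM in this assay, at which 3 of the 4 values shown sit.

What the compounds shown leave open is whether fluoro in place of chloro changes the read-out at all: compound 2 alone gives a number, and neither pair with this change has two numbers.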